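Methoxy for hydrogen on the anilide ring of compound 3

The source may hold more compounds than are shown below. What is called first, only, known or untested is meant among the compounds shown, and "the series" means these compounds.

Three amides sharing a quinoline-ether-acetanilide arrangement have been run in a physicochemical assay for lipophilicity, read by HPLC, in phosphate buffer, measured as chromatographic lipophilicity, at pH 7.4; on this read-out lower numbers stand for lower lipophilicity and higher numbers for higher lipophilicity. Compound 1 `Cc1cc(C)cc(NC(=O)COc2cc(C)nc3ccc(C(F)(F)F)cc23)c1` gives 6.67. Compound 2 `CCCc1cc(OCC(=O)Nc2cc(C)cc(C)c2)c2cc(OC)ccc2n1` gives 6.44. Compound 3 `COc1ccc2nc(C)cc(OCC(=O)Nc3ccccc3)c2c1` gives 4.28, the lowest of the three numbers; the nearest is compound 2, higher by a gap beyond the scatter, and compound 1 lies further still, also beyond the scatter. No pair among these three differs in one place only, so their gaps are not attributed to any single change.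

Compound 4 `COc1ccc(NC(=O)COc2cc(C)nc3ccc(OC)cc23)cc1` has not yet been run in this assay. It differs from compound 3 by methoxy in place of hydrogen on an aromatic carbon. The same difference, cut one bond further out, reads phenyl to 4-methoxyphenyl. Within the data shown here, no measured pair isolates this change, so the expectation rests on the change itself: a small step, probably not beyond the scatter, in either direction. Compound 4 is expected at 4.3, within 3.9 to 4.7, and the step from compound 3 to compound 4 is estimated as a number 0.02 log units higher from compound 3 to compound 4 (within the scatter).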

Compound 4, distribution coefficient: 4.22
Compound 4: middle estimate off by 0.08 log units, on the high side; the range from low to high includes it.
By their numbers in this assay, from the lowest: compounds 4 and 3 (each within the scatter of the next); then compounds 2 and 1 (each within the scatter of the next).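

In this assay, among these compounds, the first step that isolates a single change is a number 0.06 log units lower from compound 3 to compound 4 (within the scatter), for methoxy in place of hydrogen on an aromatic carbon of a six-membered aromatic ring of carbon only, para to a large group. At this position, then, adding methoxy to compound 3 leaves the read-out within the usual scatter, although this rests on one pair only. No measurement at hand accounts for this outcome.

On these data alone, whether an amine or a carboxylic acid on the same carbon would also stay within the scatter remains open, as does methoxy on the other carbons of that ring. Also open, as far as these compounds go, is whether methoxy would give a similar step on the more substituted ring carried by compound 1 and compound 2.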